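Swapping naphthalen-2-yl for 3,5-dichlorophenyl on a carbonyl carbon

The compounds below may be only part of what the source reports. "The series", "measured", "known", "first", "only" and "open" are said of these compounds alone.

In a functional assay on HCT-116 cells (Homo sapiens) for antiproliferative activity, read by MTT assay, with a stated time of 72 h (a higher number here means a weaker inhibitor, a lower number a stronger inhibitor), compound 1 `O=C(CSc1cccc(O)c1)Nc1ccc2nc(NC(=O)c3ccc(F)cc3)sc2c1` gives 6170 nM. In the same test, compound 2 `CCCC(=O)Nc1nc2ccc(NC(=O)CSc3cccc(O)c3)cc2s1` gives 10600 nM, and compound 3 `O=C(CSc1cccc(O)c1)Nc1ccc2nc(NC(=O)c3ccc4ccccc4c3)sc2c1` gives 4250 nM. The number for compound 3 is clearly separated from only one of the other two: a 2.5-fold lower number from compound 2 to compound 3 (0.40 log units; beyond the scatter), whereas a 1.5-fold lower number from compound 1 to compound 3 (0.16 log units; within the scatter) does not separate that pair.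

Compound 4 `O=C(CSc1cccc(O)c1)Nc1ccc2nc(NC(=O)c3cc(Cl)cc(Cl)c3)sc2c1` carries 3,5-dichlorophenyl in place of naphthalen-2-yl on a carbonyl carbon. For the measured compounds named here, the closest guide is the earlier exchange of one aromatic group for another at that carbon, which stayed within the scatter, and the one step beyond it involved propyl, a group absent from this change. Going by the values given here, no measured compound carries chlorine, so this guide is indirect. No step beyond the scatter is therefore expected, and the expected change is a 1.2-fold higher number from compound 3 to compound 4 (0.07 log units; within the scatter). Compound 4 is estimated at 5000 nM, with an expected range of 2300 nM to 10500 nM.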

Compound 4, half-maximal inhibitory concentration: 5440 nM
For compound 4 the middle estimate is 1.1-fold (0.04 log units) below the measured one; low and high end bracket the measured number.
By their numbers in this assay, from the lowest: compounds 3, 4, 1 and 2 (each within the scatter of the next, the first and the last beyond it).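

In this assay, 3,5-dichlorophenyl on this carbonyl carbon is not separated from either aromatic group seen there before, with a 1.3-fold higher number from compound 3 to compound 4 (0.11 log units; within the scatter) against naphthalen-2-yl and a 1.1-fold lower number from compound 1 to compound 4 (0.05 log units; within the scatter) against 4-fluorophenyl. Unlike naphthalen-2-yl, it is also not separated from propyl, with a 1.9-fold lower number from compound 2 to compound 4 (0.29 log units; within the scatter), so the step between compound 2 and compound 3 remains the only one beyond the scatter at this position. Nothing shown offers a reason for these numbers.

The compounds shown leave open whether an aromatic ring bearing an amine or a carboxylic acid at this carbonyl carbon would stand clearly apart from these four, and whether a chain longer than propyl would do so. They also leave open how much the numbers depend on the rest of the shared core.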